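Aryl substituent changes on the shared core: working notes

This account rests on a few compounds, and the source may have more. Where it says the series, first, only, none or still open, it means among the compounds named here.

Measured so far in an assay on SH-SY5Y cells for inhibition of Voltage-dependent L-type calcium channel subunit alpha-1D (Homo sapiens), read by calcium flux, with a stated time of 15 min; on this read-out lower numbers stand for stronger inhibition and higher numbers for weaker inhibition:
compound 1 `CCOC(=O)C1=C(C)NC(c2ccccc2)=CC1c1ccccc1` gives 18700 nM
compound 2 `CCOC(=O)C1=C(C)NC(c2ccccc2)=CC1c1ccc(OC)cc1` gives 29800 nM
compound 3 `CCOC(=O)C1=C(C)NC(c2ccccc2)=CC1c1ccc(C)cc1` gives 20600 nM

Compound 3 stands second highest of the three numbers; its nearest neighbour is compound 1, its furthest compound 2, and both gaps are within the scatter. Compound 4 `CCOC(=O)C1=C(C)NC(c2ccccc2)=CC1c1ccc([N+](=O)[O-])cc1` differs from compound 3 by nitro in place of methyl on an aromatic carbon. The measured steps that touch the same aromatic carbon are a 1.1-fold higher number from compound 1 to compound 3 (0.04 log units; within the scatter), a 1.6-fold higher number from compound 1 to compound 2 (0.20 log units; within the scatter) and a 1.4-fold lower number from compound 2 to compound 3 (0.16 log units; within the scatter); each lies within the scatter, so hydrogen, methoxy and methyl at that carbon have all returned the same kind of number in this assay. Among the compounds with values here, none of these steps brings in a nitro group, so the series holds no direct precedent for this particular change, and the number of heavy atoms and of acceptors entering is larger than in any step seen. On the steps seen, no step beyond the scatter is expected in either direction for compound 4, which is estimated at 21000 nM, within 8000 nM to 55000 nM. This corresponds to an expected step of a 1.0-fold higher number from compound 3 to compound 4 (0.01 log units; within the scatter). Within the data shown here, the range is kept wide since the change has no measured counterpart.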

Compound 4, half-maximal inhibitory concentration: 12200 nM
Beside the measured number, compound 4's estimate is 1.7-fold (0.24 log units) above it; the range from low to high includes it.
By their numbers in this assay, from the lowest: compounds 4, 1, 3 and 2 (each within the scatter of the next, the first and the last beyond it).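

Within the data shown here, at this aromatic carbon, nitro gives the first step to pass the scatter in this assay, a modest one against methoxy (a 2.4-fold lower number from compound 2 to compound 4 (0.39 log units; beyond the scatter)). Against methyl (a 1.7-fold lower number from compound 3 to compound 4 (0.23 log units; within the scatter)) and hydrogen (a 1.5-fold lower number from compound 1 to compound 4 (0.19 log units; within the scatter)) nitro stays within the scatter, so this change separates only the nitro and methoxy members of the set, and compound 4 cannot be called the most potent of the four. Nothing available accounts for this one separation between nitro and methoxy, which stands here as an observation only.

Still open, as far as these compounds go, is whether any group at this aromatic carbon moves the number beyond the scatter from hydrogen: an amine, a carboxylic acid, a chlorine or a longer chain there would test whether the range seen so far can be widened. Also open is whether the nitro and methoxy separation holds when the rest of the shared core changes, since the four compounds shown differ only at this one carbon.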